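Aryl group variation on the shared core, compound 4

The source may hold more compounds than are shown below. What is called first, only, known or untested is meant among the compounds shown, and "the series" means these compounds.

Of the compounds shown here, three of the shared core have been measured in a functional assay (muscle tissue) with Cavia porcellus as the target; on this read-out lower numbers stand for an effect already at smaller amounts and higher numbers for an effect only at larger amounts of compound. Compound 1 `COC(=O)C1=C(C)N=C(C)/C(=C(\O)OC)C1c1cccc([N+](C)(C)C)c1` gives 50100 nM, compound 2 `COC(=O)C1=C(C)N=C(C)/C(=C(\O)OC)C1c1cccc(C)c1` gives 110 nM, and compound 3 `COC(=O)C1=C(C)N=C(C)/C(=C(\O)OC)C1c1cccc([N+](=O)[O-])c1` gives 3.98 nM. Compound 2 stands second highest of these three numbers; compound 3 lies nearest, with a 28-fold lower number from compound 2 to compound 3 (1.44 log units; beyond the scatter), and compound 1 furthest, with a 460-fold lower number from compound 1 to compound 2 (2.66 log units; beyond the scatter). The widest span in the set is a 13000-fold lower number from compound 1 to compound 3 (4.10 log units; beyond the scatter).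

Compound 4 `COC(=O)C1=C(C)N=C(C)/C(=C(\O)OC)C1c1ccccc1OC` differs from compound 2 as follows: 2-methoxyphenyl in place of 3-methylphenyl on a saturated ring carbon. Among the measured compounds shown here, all measured steps exchange one group on a 3-substituted ring; none compares a 3-methylphenyl with a 2-methoxyphenyl, so no step bears directly on this change. Both a methyl and a nitro group on the ring gave low numbers, so a methoxy group is taken to leave the number in the same region. Compound 4 is expected to show a 1.6-fold lower number from compound 2 to compound 4 (0.20 log units; within the scatter), within the scatter. Compound 4 is estimated at 70 nM, in a range from 8 nM to 600 nM.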

Compound 4, half-maximal effective concentration: 57.5 nM
Compound 4: the middle estimate sits 1.2-fold (0.09 log units) above what was measured, within the range that was stated.
By their numbers in this assay, from the lowest: compound 3; then compounds 4 and 2 (each within the scatter of the next); then compound 1.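

The exchange of 3-methylphenyl for 2-methoxyphenyl on the saturated ring carbon reads in this assay as a 1.9-fold lower number from compound 2 to compound 4 (0.28 log units; within the scatter) and so leaves compound 2 and compound 4 indistinguishable on this read-out. The earlier steps shown here only exchanged a group on a 3-substituted phenyl, whereas this one changes the group and its place on the phenyl together, and adds a hydrogen-bond acceptor, without a shift beyond the scatter. Nothing among the available evidence accounts for this result.

The contributions of the methoxy group and of its place on the phenyl remain unseparated, and a 2-methylphenyl or 3-methoxyphenyl compound would be needed to divide them. Also open, from the compounds shown here alone, is how an amine or a carboxylic acid at the 2-place of the phenyl would read in this assay on the shared core.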